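The source may hold more compounds than are shown below. What is called first, only, known or untested is meant among the compounds shown, and "the series" means these compounds.

Measured in a physicochemical assay for solubility, at pH 1.1; a lower number here means a less soluble compound, a higher number a more soluble compound:
compound 1 `CCCN(Cc1ccc(OCCN2C(=O)CCC2=O)c(OC)c1)C(CC)c1ccc(Cl)c(C(=O)O)c1`: 3000000 nM
compound 2 `Cc1cc(CN(CC2CC2)C(CC(=O)O)c2ccc(Cl)cc2)ccc1OCCN1C(=O)CCC1=O`: 3000000 nM
compound 3 `Cc1cc(CN(CC2CC2)[C@@H](CC(=O)O)c2ccc(Cl)cc2)ccc1OCCN1C(=O)CCC1=O`: 3000000 nM

Compound 2 stands level with compounds 1 and 3 at the digits shown. Next comes compound 4 `Cc1cc(CN(CC2CCCCC2)C(CC(=O)O)c2ccc(Cl)cc2)ccc1OCCN1C(=O)CCC1=O`, which carries cyclohexyl in place of cyclopropyl on a saturated chain carbon bound to an amine nitrogen. Going by the values given here, the only measured step is no change at the digits printed from compound 2 to compound 3 (within the scatter), and the sole difference there is the fact that one of compounds 2 and 3 is drawn with a defined configuration and the other without, at the place where they differ. Among the compounds with values here, no measured step touches this group, so that step bears on the change only weakly. No shift beyond the scatter is therefore expected in this assay, and the expected step is no change at the digits printed from compound 2 to compound 4 (within the scatter). For compound 4 the estimated value is 3000000 nM, with an expected range from 1200000 nM to 3500000 nM.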

Compound 4, solubility: 3000000 nM
Estimate against measurement, compound 4: no gap at the digits printed; low and high end bracket the measured number.
By their numbers in this assay, from the lowest: compounds 1, 2, 3 and 4 (each within the scatter of the next).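

In this assay, cyclohexyl in place of cyclopropyl on a saturated chain carbon bound to an amine nitrogen gives no change at the digits printed from compound 2 to compound 4 (within the scatter). Going by these compounds alone, this is the first step at this place, as the earlier step concerned only a drawn configuration; a six-membered carbon ring is read here alongside the three-membered one without a difference in this assay. Nothing on hand accounts for this outcome.

Open, going by these compounds, is whether a straight hexyl chain, or a hydroxyl or an amine carried on the ring, would read the same at this place. On these data alone, whether cyclohexyl reads the same on the defined S configuration of compound 3 is also open.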